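This account rests on a few compounds, and the source may have more. Where it says the series, first, only, none or still open, it means among the compounds named here.

Working notes on the series. Compound 1 `CC(C)C(c1nnc[nH]1)c1ccc(-c2ccc3cccc(F)c3c2)[nH]c1=O` is the reference point; in a functional assay on CHO cells for antagonist activity at prostaglandin E2 receptor EP3 subtype (Homo sapiens), read by cAMP accumulation (on this read-out higher numbers stand for weaker inhibition and lower numbers for stronger inhibition), compound 1 gives 21 nM. Compound 2 `CC(C)C(c1ccc(-c2ccc3cccc(F)c3c2)[nH]c1=O)N1CCNC1=O` gives 28 nM, and compound 3 `CC(C)C(c1ccc(-c2ccc3cccc(F)c3c2)[nH]c1=O)N1CCN/C1=N\C#N` gives 38 nM. The number for compound 1 is the lowest of the three, but both steps away from it stay inside the scatter: a 1.3-fold higher number from compound 1 to compound 2 (0.12 log units; within the scatter), and a 1.8-fold higher number from compound 1 to compound 3 (0.26 log units; within the scatter). Between the other two, a 1.4-fold higher number from compound 2 to compound 3 (0.13 log units; within the scatter), so the three substituents on a saturated chain carbon bound to an aromatic carbon and a saturated chain carbon have so far given numbers that cannot be told apart.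

Compound 4 `Cc1nc(C(c2ccc(-c3ccc4cccc(F)c4c3)[nH]c2=O)C(C)C)[nH]c1C` continues this line. Its difference from compound 1 is 4,5-dimethyl-1H-imidazol-2-yl in place of 4H-1,2,4-triazol-3-yl on a saturated chain carbon bound to an aromatic carbon and a saturated chain carbon. Within the data shown here, the steps that bear on it are the two from compound 1, both exchanges of the same group at the same place, and both within the scatter. On that basis no step beyond the scatter is expected in this assay for compound 4, in either direction; the number is expected to sit close to that of compound 1, with the step from compound 1 to compound 4 estimated as a 1.4-fold higher number from compound 1 to compound 4 (0.15 log units; within the scatter). Compound 4 is therefore estimated at 30 nM, with a range from 12 nM to 75 nM.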

Compound 4, half-maximal inhibitory concentration: 50 nM
Estimate against measurement, compound 4: 1.7-fold (0.22 log units) below, and the stated range covers the measured number.
By their numbers in this assay, from the lowest: compounds 1, 2, 3 and 4 (each within the scatter of the next, the first and the last beyond it).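

In this assay, among these compounds, 4,5-dimethyl-1H-imidazol-2-yl in place of 4H-1,2,4-triazol-3-yl gives the first step at this position that lies beyond the scatter, though a modest one: a 2.4-fold higher number from compound 1 to compound 4 (0.38 log units; beyond the scatter). The separation holds only against compound 1, since the same group stays within the scatter of the two non-aromatic ring groups, with a 1.8-fold higher number from compound 2 to compound 4 (0.25 log units; within the scatter) and a 1.3-fold higher number from compound 3 to compound 4 (0.12 log units; within the scatter), so the position is sensitive to this exchange without the four compounds falling into distinct levels. The entering group differs from the leaving one in both its ring hetero atoms and its heavy atom count, and no measurement on hand accounts for the step.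

Still open, from the compounds shown here alone, is whether the step follows from the two methyl groups or from the change of ring, a question that the unsubstituted 1H-imidazol-2-yl at the same place would address. Also open, going by these compounds, is how the number responds when the five-membered ring on this saturated chain carbon gives way to a group with no ring, such as an amine or a carboxylic acid.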